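The compounds below may be only part of what the source reports. "The series", "measured", "known", "first", "only" and "open" are said of these compounds alone.

Compound 1 `Cn1ncc(Cl)c1-c1cc(C(=O)N[C@@H]2CN[C@H](CCn3cncn3)C[C@H]2c2ccc(Cl)c(Cl)c2)oc1Cl` was tested in a functional assay on OVCAR-8 cells (Homo sapiens) for antiproliferative activity (on this read-out higher numbers stand for weaker inhibition and lower numbers for stronger inhibition), and gave 1560 nM. Among the three compounds measured, this is the highest number. Compound 2 `Cn1ncc(Cl)c1-c1cc(C(=O)N[C@H]2CNCC[C@@H]2c2ccc(C(F)(F)F)cc2)oc1Cl` gives 900 nM in this assay, and this value lies within the usual scatter of the number for compound 1, so the two cannot be ordered. Among the measured compounds shown here, compound 3 `Cn1ncc(Cl)c1-c1cc(C(=O)N[C@@H]2CN[C@H](CCO)C[C@H]2c2ccc(F)c(F)c2)oc1Cl` gives 460 nM in this assay, a value that stands beyond the scatter from compound 1 and thus marks the one clearly lower number in the set. Compound 3 differs from compound 1 in more than one place, so its gap is not attributed to any single change.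

Compound 4 `Cn1ncc(Cl)c1-c1cc(C(=O)N[C@@H]2CN[C@H](CCN3CCC(O)CC3)C[C@H]2c2ccc(Cl)c(Cl)c2)oc1Cl` has not yet been measured in this assay. It differs from compound 1 in one place: 4-hydroxypiperidin-1-yl in place of 1H-1,2,4-triazol-1-yl on a saturated chain carbon, two bonds along the chain from a saturated ring carbon. No measured pair isolates this change, so the expectation rests on the range shown by compounds 1, 2 and 3. Compound 4 is expected to give a number close to that of compound 1, with a step of a 1.6-fold lower number from compound 1 to compound 4 (0.19 log units; within the scatter) that would not clearly exceed the scatter. Compound 4 is thus estimated at 1000 nM, within 300 nM to 3300 nM.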

Compound 4, half-maximal inhibitory concentration: 15900 nM
Compound 4: the middle estimate sits 16-fold (1.20 log units) below what was measured; the measured number lies above the stated range.
By their numbers in this assay, from the lowest: compounds 3, 2 and 1 (each within the scatter of the next, the first and the last beyond it); then compound 4.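

In this assay, 4-hydroxypiperidin-1-yl in place of 1H-1,2,4-triazol-1-yl on a saturated chain carbon, two bonds along the chain from a saturated ring carbon, gives a 10-fold higher number from compound 1 to compound 4 (1.01 log units; beyond the scatter). Among the compounds shown here, this is the only pair in the set that isolates a single change, and it shows that the group carried by this ethyl chain can move the read-out well beyond the scatter while the rest of compound 1 stays the same. The data shown offer no measurement that accounts for the size of this step.

The compounds shown leave open whether the step follows the piperidine ring or its hydroxyl group, a question that a plain piperidin-1-yl or a morpholin-4-yl group on the same chain would address. They also leave open how a 1H-imidazol-1-yl group or a longer chain would read at this position.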